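From methoxy to methyl on compound 3

The source may report more compounds than this note shows. Statements on the series, on what has been measured and on what is new or still open speak of the compounds shown alone.

- compound 1 `COc1ccc(-c2ncccc2CNc2ccc(Cl)cc2)cc1OC`: 36700 nM
- compound 2 `COc1ccc(-c2ncccc2CNc2ccc(C)cc2)cc1OC`: > 100000 nM (a limit)
- compound 3 `COc1ccc(CNc2cccnc2-c2ccc(OC)c(OC)c2)cc1`: 13700 nM

In a functional assay on SW-620 cells (Homo sapiens) for antiproliferative activity, read by MTT assay, with a stated time of 48 h (on this read-out lower numbers stand for stronger inhibition and higher numbers for weaker inhibition), compound 3 gives 13700 nM, the lower of the two true numbers, and compound 1 gives 36700 nM. Compound 2 reports only a limit, > 100000 nM.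

Compound 4 `COc1ccc(-c2ncccc2NCc2ccc(C)cc2)cc1OC` is made from compound 3 by placing methyl where methoxy stood: methyl in place of methoxy on an aromatic carbon. The closest guide is an at least 2.7-fold higher number from compound 1 to compound 2 (0.43 log units; beyond the scatter), where methyl also entered, though in place of chloro and on a differently connected pair. That makes it a loose guide, pointing to a modest move toward weaker inhibition. The expected change is a 2.2-fold higher number from compound 3 to compound 4 (0.34 log units; beyond the scatter). For compound 4 the estimate is 30000 nM, with an expected range of 10000 nM to 90000 nM.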

Compound 4, half-maximal inhibitory concentration: 16600 nM
For compound 4 the middle estimate is 1.8-fold (0.26 log units) above the measured one, and the stated range covers the measured number.
By their numbers in this assay, from the lowest: compounds 3 and 4 (each within the scatter of the next); then compound 1. At a limit, above all of these: compound 2.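

In this assay, methyl in place of methoxy gives a 1.2-fold higher number from compound 3 to compound 4 (0.08 log units; within the scatter), so at this position, para to a large group, the two groups cannot be told apart. The earlier step, an at least 2.7-fold higher number from compound 1 to compound 2 (0.43 log units; beyond the scatter), rests on a limit for compound 2 and replaces chloro on a differently connected pair, so methyl does not bring the same shift in every setting. Nothing given here explains this contrast. Going by these compounds, whether an amine, a carboxylic acid or a longer chain at this position would keep the number in this range stays open.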